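The source may report more compounds than this note shows. Statements on the series, on what has been measured and on what is new or still open speak of the compounds shown alone.

In a functional assay on 3T3-L1 cells (Mus musculus) for inhibition, with a stated time of 20 min, tested at 20 uM (a lower number here means less inhibition, a higher number more inhibition at the concentration tested (going by the name of the read-out)), compound 2, with the structure `Cc1ccc(S(=O)(=O)N(Cc2cn(Cc3ccc(F)cc3F)nn2)Cc2cn(S(=O)(=O)c3ccc(C)cc3)c3ccccc23)cc1`, gives 12.3%, the highest of the two numbers recorded. Its nearest neighbour is compound 1, with the structure `COc1ccc(Cn2cc(CN(Cc3cn(S(=O)(=O)c4ccc(C)cc4)c4ccccc34)S(=O)(=O)c3ccc(C)cc3)nn2)c(OC)c1`, which in this assay gives 7.6%; the step of a number 4.7 percentage points higher from compound 1 to compound 2 (within the scatter) lies within the scatter of the method. The account now turns to compound 3, with the structure `Cc1ccc(S(=O)(=O)N(Cc2cn(Cc3ccccc3)nn2)Cc2cn(S(=O)(=O)c3ccc(C)cc3)c3ccccc23)cc1`, which differs from compound 2 by phenyl in place of 2,4-difluorophenyl on a saturated chain carbon bound to an aromatic nitrogen. Within the data shown here, the only measured step that bears on this change is the one from compound 1 to compound 2, which exchanged the group on the same saturated chain carbon bound to an aromatic nitrogen and moved the read-out by no more than the scatter. On that basis no step beyond the scatter is expected here, so compound 3 is estimated to give 10%, between 0% and 25%, a change of a number 2.3 percentage points lower from compound 2 to compound 3 (within the scatter) from compound 2.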

Compound 3, a percentage reported as inhibition, at one concentration (the size of the read-out at that concentration, not a potency): 3.4%
For compound 3 the middle estimate is 6.6 percentage points above the measured one; measured number inside the range.
By their numbers in this assay, from the lowest: compounds 3, 1 and 2 (each within the scatter of the next).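

In this assay, the unsubstituted ring now stands with the two substituted ones on this saturated chain carbon bound to an aromatic nitrogen, with a number 8.9 percentage points lower from compound 2 to compound 3 (within the scatter) when 2,4-difluorophenyl gives way to phenyl and a number 4.2 percentage points lower from compound 1 to compound 3 (within the scatter) when 2,4-dimethoxyphenyl does. Among these compounds, removing either pair of substituents therefore gives no step the method can resolve, and all three compounds lie within the scatter of one another. No independent evidence bears on this result.

The compounds shown leave open whether any group at this position can move the read-out beyond the scatter. From the compounds shown here alone, a benzyl ring carrying an amine or a carboxylic acid, or a longer chain in place of the benzyl group, remains untested in this account.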